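Swapping the anilide ring on a shared thiazolidinedione core

The source may report more compounds than this note shows. Statements on the series, on what has been measured and on what is new or still open speak of the compounds shown alone.

Three measured compounds share one core and differ only in the group on the amide nitrogen: compound 1 `Cc1cccc2sc(NC(=O)COc3ccc(/C=C4\SC(=O)NC4=O)cc3)nc12`, compound 2 `O=C(COc1ccc(/C=C2\SC(=O)NC2=O)cc1)Nc1cccc([N+](=O)[O-])c1` and compound 3 `O=C(COc1ccc(/C=C2\SC(=O)NC2=O)cc1)Nc1ccc(Cl)cc1C(F)(F)F`. All were tested in a functional assay on PC-3 cells (Homo sapiens) for inhibition; a lower number here means a stronger inhibitor of growth, a higher number a weaker inhibitor of growth. In this assay compound 1 reached only the assay limit of > 100000 nM, a limit and not a number. Compound 2 likewise stopped at the limit of > 100000 nM. Compound 3 too gave no number, only the limit of > 100000 nM. Among the compounds with values here, compound 2 thus stands exactly where the whole set stands, at the limit of > 100000 nM in this assay, at which 3 of the 3 values shown sit, and no step between measured compounds can be computed.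

Compound 4 `O=C(COc1ccc(/C=C2\SC(=O)NC2=O)cc1)Nc1c(Cl)cccc1Cl` is not yet measured. It differs from compound 2 in one place (2,6-dichlorophenyl in place of 3-nitrophenyl on an amide-type nitrogen). Within the data shown here, since no measured step exists, the step that the limit leaves unreadable from compound 2 to compound 4 is expected to be none beyond the scatter, with the reading most likely again a limit. Compound 4 is estimated at 150000 nM in this assay, within a range from 30000 nM to 1000000 nM.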

Compound 4, concentration for 50% growth inhibition: > 100000 nM
Compound 4 was reported as a limit; the forecaster's own chance of this, stated with the estimate: 80%; the middle value does not contradict the limit.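

Within the data shown here, compound 2 and compound 4 both gave a limit and not a number, so no step between them can be read: the limit of > 100000 nM in this assay, at which 4 of the 4 values shown sit.

In this assay the compounds shown leave open whether any group on the amide nitrogen of the shared core would give a readable number, and how such groups would rank.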